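From a silent naphthyl analogue toward a smaller hydroxyphenyl

The source may hold more compounds than are shown below. What is called first, only, known or untested is meant among the compounds shown, and "the series" means these compounds.

This account follows a small series built on one shared core and tested in a functional assay on Ehrlich cells (Mus musculus) for cytotoxicity; on this read-out higher numbers stand for weaker inhibition and lower numbers for stronger inhibition. Compound 1 `COc1cc(N2C(N)=C(C#N)C(c3c(O)ccc4ccccc34)C3=C2CC(C)(C)CC3=O)cc(OC)c1OC` carries a 2-hydroxynaphthalen-1-yl group on a saturated ring carbon and in this assay compound 1 gives 143000 nM. Among the compounds with values here, compound 2 `COc1ccccc1C1C(C#N)=C(N)N(c2cc(OC)c(OC)c(OC)c2)C2=C1C(=O)CC(C)(C)C2` has 2-methoxyphenyl in that place, and in this assay compound 2 gives 26600 nM; the move a 5.4-fold lower number from compound 1 to compound 2 (0.73 log units; beyond the scatter) is the only step within the measured set. Compound 3 `COc1cc(N2C(N)=C(C#N)C(c3c(OC)ccc4ccccc34)C3=C2CC(C)(C)CC3=O)cc(OC)c1OC` carries 2-methoxynaphthalen-1-yl, and in this assay compound 3 is reported as "not active" (no number reported), so no number stands for it at all; on the numbers shown, compound 3 is the one analogue without any measured inhibition.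

Compound 4 `COc1cc(N2C(N)=C(C#N)C(c3ccccc3O)C3=C2CC(C)(C)CC3=O)cc(OC)c1OC` differs from compound 3 in one place: 2-hydroxyphenyl in place of 2-methoxynaphthalen-1-yl on a saturated ring carbon. Within the data shown here, the single measured step bears on it only loosely, since the change from compound 1 to compound 2 also swapped a naphthalene ring for a single phenyl ring, and that step lowered the number modestly, while compound 1 with its hydroxy group gave a number where compound 3 with a methoxy group gave none. Compound 4 is therefore expected to show measurable inhibition, estimated at 50000 nM, in a range from 15000 nM to 200000 nM.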

Compound 4, half-maximal inhibitory concentration: "not active" (no number reported)
Nothing numeric was reported for compound 4; there is nothing to compare the estimate with.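

Compound 4, like compound 3, is reported as "not active" in this assay, so no new step can be read between them. Nothing measured here offers an explanation for this result. The compounds shown leave open how 2-hydroxyphenyl and 2-methoxynaphthalen-1-yl compare in that assay, since neither compound has a number.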